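A Swapped Oxadiazole and Dog Clearance

The source may hold more compounds than are shown below. What is called first, only, known or untested is meant among the compounds shown, and "the series" means these compounds.

Measured in an in vivo ADME assay on the whole organism for pharmacokinetics, with Canis familiaris (Canis lupus familiaris) as the target, at a dose of 1 mg/kg by the intravenous route; a lower number here means slower removal, a higher number faster removal of the compound:
- compound 1 `C[C@@H](Nc1nccc(Cl)c1NC(=O)CC#N)c1ccc(-c2cccc(F)c2C(F)(F)F)cc1`: "not determined" (no result reported)
- compound 2 `Cc1noc(-c2c(F)cccc2-c2ccc([C@@H](C)Nc3nccc(Cl)c3NC(=O)CC#N)cc2)n1`: 7.3 mL/min/kg

Among the compounds with values here, compound 2 carries the only number in this assay; compound 1 stands beside it without a result, so compound 2 cannot be ranked against anything. Compound 3 `Cc1nc(-c2c(F)cccc2-c2ccc([C@@H](C)Nc3nccc(Cl)c3NC(=O)CC#N)cc2)no1` has the same atoms as compound 2, joined differently: 5-methyl-1,2,4-oxadiazol-3-yl in place of 3-methyl-1,2,4-oxadiazol-5-yl on an aromatic carbon. Within the data shown here, no step between two measured compounds is available to guide the expectation, so the forecast rests on compound 2 alone. Since the change keeps the group's size and its counts of donors and acceptors unchanged, the step of a 1.1-fold higher number from compound 2 to compound 3 (0.04 log units; within the scatter) is expected to stay within the usual scatter, with no direction favoured. Compound 3 is therefore estimated at 8 mL/min/kg in this assay, with a range from 4 mL/min/kg to 16 mL/min/kg.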

Compound 3, clearance: 5.9 mL/min/kg
Compound 3: middle estimate off by 1.4-fold (0.13 log units), on the high side, within the range that was stated.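

In this assay, placing 5-methyl-1,2,4-oxadiazol-3-yl instead of 3-methyl-1,2,4-oxadiazol-5-yl on the aromatic carbon ortho to a fluoro group and ortho to a large group gives a 1.2-fold lower number from compound 2 to compound 3 (0.09 log units; within the scatter). Within the data shown here, this is the first step that can be read at this position, and it shows that the two ways of joining the same ring cannot be told apart by clearance in the dog. Nothing available speaks to a reason for this result.

As far as these compounds go, whether a carboxylic acid or a primary amide on the same aromatic carbon would give a clearance in the same range remains open. So does whether an ethyl or a longer chain in place of the methyl on either oxadiazole would move the number beyond the scatter.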